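Isopropoxy to 2,2,2-trifluoroethoxy on the shared core

This account rests on a few compounds, and the source may have more. Where it says the series, first, only, none or still open, it means among the compounds named here.

In a functional assay on MCF7 cells (Homo sapiens) for antiproliferative activity, read by MTT assay, with a stated time of 48 h (a higher number here means a weaker inhibitor, a lower number a stronger inhibitor), compound 1 `COc1cc(-c2nnc3c(OC)cc(-c4ccc5c(ccn5C)c4)cn23)cc(OC)c1OC` gives 49 nM and compound 2 `COc1cc(-c2nnc3c(OC(C)C)cc(-c4ccc5c(ccn5C)c4)cn23)cc(OC)c1OC` gives 204 nM as the higher of the two numbers. Compound 3 `COc1cc(-c2nnc3c(OCC(F)(F)F)cc(-c4ccc5c(ccn5C)c4)cn23)cc(OC)c1OC` differs from compound 2 by 2,2,2-trifluoroethyl in place of isopropyl on an oxygen on an aromatic ring and so has 2,2,2-trifluoroethyl in place of isopropyl on an oxygen on an aromatic ring. For the measured compounds named here, only one measured step involves a change on this oxygen (a 4.2-fold higher number from compound 1 to compound 2 (0.62 log units; beyond the scatter)) and it is modest. A small shift toward the lower number is therefore expected, probably within the scatter (estimated as a 1.4-fold lower number from compound 2 to compound 3 (0.13 log units; within the scatter)). Compound 3 is expected at about 150 nM (estimated range 55 nM to 400 nM).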

Compound 3, half-maximal inhibitory concentration: 382 nM
For compound 3 the middle estimate is 2.5-fold (0.41 log units) below the measured one; measured number inside the range.
By their numbers in this assay, from the lowest: compound 1; then compounds 2 and 3 (each within the scatter of the next).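

Changing isopropyl to 2,2,2-trifluoroethyl on this oxygen gives a 1.9-fold higher number from compound 2 to compound 3 (0.27 log units; within the scatter) in this assay, so these two groups cannot be told apart here. The trifluoromethyl in place of hydrogen on the methoxy group, however, gives a 7.8-fold higher number from compound 1 to compound 3 (0.89 log units; beyond the scatter), so a second replacement of the methyl now also lies beyond the scatter. Nothing available explains this difference. On these data alone, whether an ethyl group on this oxygen would stay close to compound 1 remains open. So does the outcome with a longer chain, or with an amine in place of the whole alkoxy group.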